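Ester chain variation at the pyrrole carboxylate and receptor agonism

The source may hold more compounds than are shown below. What is called first, only, known or untested is meant among the compounds shown, and "the series" means these compounds.

Measured so far:
compound 1 `C=CCN(C)C(=O)c1ccc(C(CC)(CC)c2ccc(OCC(=O)C(C)(C)C)c(C)c2)n1CC` — 21600 nM
compound 2 `C#CC(C)OC(=O)c1ccc(C(CC)(CC)c2ccc(OCC(=O)C(C)(C)C)c(C)c2)n1CC` — 210 nM
compound 3 `C#CCCOC(=O)c1ccc(C(CC)(CC)c2ccc(OCC(=O)C(C)(C)C)c(C)c2)n1CC` — 28800 nM

These three share one core and differ only in the group on a carbonyl carbon. In an assay on HL-60 cells for agonist activity at vitamin D3 receptor (Homo sapiens), read by microscopy, with a stated time of 96 h (on this read-out lower numbers stand for an effect already at smaller amounts and higher numbers for an effect only at larger amounts of compound), compound 3 gives the highest number of the three; its nearest neighbour is compound 1, with a 1.3-fold higher number from compound 1 to compound 3 (0.12 log units; within the scatter), while its furthest is compound 2, with a 140-fold higher number from compound 2 to compound 3 (2.14 log units; beyond the scatter).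

Compound 4 `CCOC(=O)CC(C)OC(=O)c1ccc(C(CC)(CC)c2ccc(OCC(=O)C(C)(C)C)c(C)c2)n1CC` has not been measured. It differs from compound 3 by 1-((ethoxycarbonyl)methyl)ethyl in place of but-3-yn-1-yl on an oxygen next to a carbonyl group. Among the compounds with values here, the only measured step that changes the group on that same oxygen is the one from compound 2 to compound 3, a 140-fold higher number from compound 2 to compound 3 (2.14 log units; beyond the scatter), which shows that this part of the molecule can move the number a great deal. The entering group of compound 4 matches neither the group of compound 2 nor that of compound 3, so the size of the effect is uncertain. A number lower than that of compound 3 is expected, with a 7.2-fold lower number from compound 3 to compound 4 (0.86 log units; beyond the scatter), and compound 4 is estimated at 4000 nM, within a range of 400 nM to 30000 nM.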

Compound 4, half-maximal effective concentration: > 50000 nM
Compound 4: only a limit was reported (the forecaster's own chance of this, stated with the estimate: 10%); middle value at least 12-fold (1.09 log units) away from the limit.
By their numbers in this assay, from the lowest: compound 2; then compounds 1 and 3 (each within the scatter of the next). At a limit, above all of these: compound 4.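

In this assay compound 4 gives only a limit, not a number: the limit of > 50000 nM in this assay, at which 1 of the 4 values shown sits. Compound 2 and compound 4 share the methyl-bearing chain carbon on the oxygen, so this pair isolates one change, and (ethoxycarbonyl)methyl in place of ethynyl gives an at least 230-fold higher number from compound 2 to compound 4 (2.37 log units; beyond the scatter), showing that this branched carbon alone does not keep the low number. The other two steps are also only floors: an at least 1.7-fold higher number from compound 3 to compound 4 (0.23 log units; that floor lies within the scatter), and an at least 2.3-fold higher number from compound 1 to compound 4 (0.36 log units; beyond the scatter).

From the compounds shown here alone, it remains open whether a plain ethyl group on that same carbon, or a carboxylic acid in place of the ethyl ester, would stay close to compound 2 at 210 nM. Going by these compounds, how far the true value of compound 4 lies past its limit also stays open.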